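The source may hold more compounds than are shown below. What is called first, only, known or untested is meant among the compounds shown, and "the series" means these compounds.

Compound 1 `O=C(NCCCNc1cc(-c2cn(-c3ccccc3)nc2-c2cccc(O)c2)ccn1)Nc1ccc(F)cc1`: 540 nM
Compound 2 `O=C(NCCCNc1cc(-c2cn(-c3ccccc3)nc2-c2cccc(O)c2)ccn1)Nc1cccc(C(F)(F)F)c1`: 740 nM

In a functional assay on SNB-75 cells (Homo sapiens) for antiproliferative activity, read by sulforhodamine B assay, with a stated time of 48 h (a higher number here means a weaker inhibitor, a lower number a stronger inhibitor), compound 1 gives 540 nM, and compound 2 gives 740 nM. Among the compounds with values here, these are the only two measurements so far, and they lie within the scatter of each other, so compound 1 has no clear rank of its own.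

Compound 3 `COc1cccc(-c2nn(-c3ccccc3)cc2-c2ccnc(NCCCNC(=O)Nc3ccc(F)cc3)c2)c1` keeps the core and the 4-fluorophenyl group of compound 1 and changes one place: methyl in place of hydrogen on an oxygen on an aromatic ring. This turns hydroxy into methoxy, making the 3-hydroxyphenyl group a 3-methoxyphenyl group.

Within the data shown here, the only measured step is a 1.4-fold higher number from compound 1 to compound 2 (0.14 log units; within the scatter). It swaps a different group, 3-(trifluoromethyl)phenyl in place of 4-fluorophenyl on an amide-type nitrogen, so it says nothing directly about this hydroxy to methoxy change. Among the measured compounds shown here, no measured compound shows what that change does, so its direction is open. A modest step towards a higher number in this assay is only a cautious guess, and the range must stay wide.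

The expected size of the change is a 1.4-fold higher number from compound 1 to compound 3 (0.14 log units; within the scatter).

For compound 3 the estimated value is 750 nM, with an expected range from 250 nM to 2500 nM.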

Compound 3, half-maximal inhibitory concentration: 4180 nM
Beside the measured number, compound 3's estimate is 5.6-fold (0.75 log units) below it; measured number outside the range, above it.
By their numbers in this assay, from the lowest: compounds 1 and 2 (each within the scatter of the next); then compound 3.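

In this assay, the hydroxy of the 3-hydroxyphenyl group is the only place among the compounds shown where a single change moves the number beyond the scatter, with a 7.7-fold higher number from compound 1 to compound 3 (0.89 log units; beyond the scatter) as methyl replaces the hydrogen on that oxygen. One added heavy atom therefore counts for more here than the swap on the amide-type nitrogen, where the compounds show a 1.4-fold higher number from compound 1 to compound 2 (0.14 log units; within the scatter) and remain within the scatter of each other. Nothing further is at hand that explains the hydroxy to methoxy step.

The compounds shown leave open whether the step comes from losing the hydrogen on the oxygen or from gaining the carbon, a question that a plain phenyl group or an amine in place of the hydroxy would help to separate, and whether a longer chain on the oxygen, such as ethoxy, would move the number further the same way. They also leave open whether the hydroxy to methoxy change has a similar size when 3-(trifluoromethyl)phenyl sits on the amide-type nitrogen in place of 4-fluorophenyl.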